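Swapping the ring on the amide nitrogen: from compound 3 to compound 4

The source may report more compounds than this note shows. Statements on the series, on what has been measured and on what is new or still open speak of the compounds shown alone.

Compound 1 `COc1ccccc1N1C(=O)C(C)SC1c1cccc(C(=O)NCCCCc2ccccc2)c1`: 95%
Compound 2 `COc1ccc(OC)c(N2C(=O)CSC2c2cccc(C(=O)NCCCCc3ccccc3)c2)c1`: 20%
Compound 3 `COc1cccc(OC)c1N1C(=O)CSC1c1cccc(C(=O)NCCCCc2ccccc2)c1`: 95%

In a functional assay on HOS-TE85 cells (Homo sapiens) for inhibition, read by CCK-8 assay, with a stated time of 72 h, tested at 1 uM (on this read-out lower numbers stand for less inhibition and higher numbers for more inhibition at the one concentration tested (going by the name of the read-out)), compound 3 stands level with compound 1 at the digits shown, the two together the highest of the three numbers, while compound 2 lies far lower. Going by the values given here, the one step measured in one place, a number 75 percentage points higher from compound 2 to compound 3 (beyond the scatter), shows how much the pattern of the ring on the amide-type nitrogen can matter. Compound 4 `COc1ccc(F)cc1N1C(=O)CSC1c1cccc(C(=O)NCCCCc2ccccc2)c1` differs from compound 3 as follows: 5-fluoro-2-methoxyphenyl in place of 2,6-dimethoxyphenyl on an amide-type nitrogen in a ring. Among the compounds with values here, no measured step covers this exact change; the 5-fluoro-2-methoxyphenyl resembles the 2,5-dimethoxyphenyl of compound 2 more closely than the 2,6-dimethoxyphenyl of compound 3, so a drop is expected, though its size is uncertain, estimated as a number 45 percentage points lower from compound 3 to compound 4 (beyond the scatter). Compound 4 is therefore expected to give 50%, between 15% and 92%.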

Compound 4, a percentage reported as inhibition, at one concentration (the size of the read-out at that concentration, not a potency): 95%
The estimate for compound 4 lay 45 percentage points below the measured number; measured number outside the range, above it.
By their numbers in this assay, from the lowest: compound 2; then compounds 1, 3 and 4 (each within the scatter of the next).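

In this assay, fluoro in place of methoxy on an aromatic carbon gives a number 75 percentage points higher from compound 2 to compound 4 (beyond the scatter), so the low number of compound 2 is tied to that one methoxy group, not to having a group at that carbon at all. 5-Fluoro-2-methoxyphenyl in place of 2,6-dimethoxyphenyl gives no change at the digits printed from compound 3 to compound 4 (within the scatter), so two different rings on the amide-type nitrogen serve equally well here. Nothing measured gives a reason for this swing.

From the compounds shown here alone, whether a chloro group, an amine or a hydroxyl at that carbon would behave like fluoro or like methoxy stays open.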